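A few compounds are considered here, and "the series" means these few. Any claim that something is new, unique, unknown or untested is made for them only; others in the source may bear on it.

The measured compounds are:

Compound 1, `CCCC1=C(C(=O)OCC)C(c2cccc([N+](=O)[O-])c2)C(C(=O)OCC)=C(C)N1`, which in a functional assay on HEK293 cells for antagonist activity at Voltage-dependent L-type calcium channel subunit alpha-1C (Oryctolagus cuniculus), read by FLIPR (a higher number here means a weaker inhibitor, a lower number a stronger inhibitor), gives 18 nM.
Compound 2, `CCCCC1=C(C(=O)OCC)C(c2cccc([N+](=O)[O-])c2)C(C(=O)OCC)=C(C)N1`, which in this assay gives 20 nM.
Compound 3, `CCOC(=O)C1=C(C)NC(COC)=C(C(=O)OC)C1c1cccc([N+](=O)[O-])c1`, which in this assay gives 14 nM.

Compound 1 and compound 2 share one core and differ only in a side chain: hydrogen in place of methyl on a saturated chain carbon, three bonds along the chain from a double-bonded ring carbon. This shortening of the chain made a step of a 1.1-fold lower number from compound 2 to compound 1 (0.05 log units; within the scatter), so the two values cannot be told apart by this kind of measurement.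

Compound 3 sits on a differently substituted core; the difference between the core of compound 3 and the core of compound 2 is not broken down here. Compound 4, `COCC1=C(C(=O)OC)C(c2cccc([N+](=O)[O-])c2)C(C(=O)OC)=C(C)N1`, has not yet been measured. It differs from compound 3 by hydrogen in place of methyl on a saturated chain carbon bound to an oxygen next to a carbonyl group. For the measured compounds named here, this is the same kind of change as the one from compound 2 to compound 1, a methyl leaving and a hydrogen entering, but the surroundings differ: in compound 1 the place is a saturated chain carbon three bonds along the chain from a double-bonded ring carbon, while in compound 4 it is a saturated chain carbon bound to an oxygen next to a carbonyl group.

Because a 1.1-fold lower number from compound 2 to compound 1 (0.05 log units; within the scatter) stayed within the scatter, the step from compound 3 to compound 4 in this assay is expected to be small as well, estimated at a 1.1-fold higher number from compound 3 to compound 4 (0.06 log units; within the scatter). Compound 4 is therefore expected to give about 16 nM, with a likely range from 7 nM to 40 nM.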

Compound 4, half-maximal inhibitory concentration: 115 nM
Estimate against measurement, compound 4: 7.2-fold (0.86 log units) below; the whole stated range lies below it.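

In this assay, putting hydrogen in place of methyl on a saturated chain carbon bound to an oxygen next to a carbonyl group turns an ethoxycarbonyl into a methoxycarbonyl and gives a clear step, an 8.2-fold higher number from compound 3 to compound 4 (0.91 log units; beyond the scatter). Set beside the earlier case, the same kind of change does not behave alike on the two cores: the same change on two cores in this assay, a 1.1-fold lower number (0.05 log units; within the scatter) from compound 2 to compound 1 and an 8.2-fold higher number (0.91 log units; beyond the scatter) from compound 3 to compound 4, 9.1-fold (0.96 log units) apart, beyond the scatter of two such steps

So in this series, the small effect of removing a methyl at one place on one core cannot be assumed to carry over to another place on another core, although this rests on only two pairs and does not show why they differ: the place of the change and the rest of the core differ together, and these compounds cannot separate the two.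

From the compounds shown here alone, it remains open whether the same change from ethoxycarbonyl to methoxycarbonyl would give a step of similar size on the core of compound 1, where the surroundings of that group are otherwise different. Also open, going by these compounds, is how the activity of compound 3 would respond at this place to a longer chain, or to a carboxylic acid or an amide in place of the ester.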